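Ring contraction at the amine of compound 1

A few compounds are considered here, and "the series" means these few. Any claim that something is new, unique, unknown or untested is made for them only; others in the source may bear on it.

Compound 1 `NC(=O)CN1CCC2(N3CCCCC3)CC(c3ccc(Cl)cc3)C1C(c1ccc(Cl)cc1)C2` carries a primary amide on the side chain and a piperidin-1-yl group on the shared core. In an ADME assay on L6 cells (Rattus norvegicus) for cytotoxicity, read by resazurin assay, with a stated time of 72 h (on this read-out higher numbers stand for weaker inhibition and lower numbers for stronger inhibition), compound 1 gives 23800 nM. Its ethyl ester analogue, compound 2 `CCOC(=O)CN1CCC2(N3CCCCC3)CC(c3ccc(Cl)cc3)C1C(c1ccc(Cl)cc1)C2`, gives 13100 nM in this assay, and the step of a 1.8-fold lower number from compound 1 to compound 2 (0.26 log units; within the scatter) lies within the scatter, so the two numbers cannot be ordered. The free acid, compound 3 `O=C(O)CN1CCC2(N3CCCCC3)CC(c3ccc(Cl)cc3)C1C(c1ccc(Cl)cc1)C2`, gives "not determined" (no result reported) in this assay, that is, no result is reported for it. Among the two numbers available, compound 1 has the highest, with compound 2 as its only neighbour and within the scatter of it.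

Compound 4 `NC(=O)CN1CCC2(N3CCCC3)CC(c3ccc(Cl)cc3)C1C(c1ccc(Cl)cc1)C2` is the next member. Relative to compound 1 the change is pyrrolidin-1-yl in place of piperidin-1-yl on a saturated ring carbon. Among the compounds with values here, no measured step touches this saturated ring carbon: the only step recorded, from compound 1 to compound 2, concerns the carbonyl carbon of the side chain and was itself within the scatter. There is therefore nothing in the series that points to a change in this assay beyond the scatter in either direction for compound 4, and the side chain of compound 1 is kept unchanged.

Compound 4 is expected to give about 22000 nM in this assay, within the range 8000 nM to 60000 nM, which means an expected step of a 1.1-fold lower number from compound 1 to compound 4 (0.03 log units; within the scatter).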

Compound 4, half-maximal inhibitory concentration: 23900 nM
Beside the measured number, compound 4's estimate is 1.1-fold (0.04 log units) below it, within the range that was stated.
By their numbers in this assay, from the lowest: compounds 2, 1 and 4 (each within the scatter of the next).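

Within the data shown here, the step of a 1.0-fold higher number from compound 1 to compound 4 (0.00 log units; within the scatter) is the first reading at this saturated ring carbon of the shared core, and it shows that in this assay the five-membered pyrrolidin-1-yl ring and the six-membered piperidin-1-yl ring cannot be told apart when the primary amide side chain is kept. With the earlier step of a 1.8-fold lower number from compound 1 to compound 2 (0.26 log units; within the scatter) on the carbonyl carbon of the side chain, both positions now have a one-place change on compound 1, and neither step lies beyond the scatter. No measurement in hand bears on why this ring change leaves the reading within the scatter.

The compounds shown cover only two saturated cyclic amines at this carbon, so it remains open whether an open-chain amine such as dimethylamino, or a ring with a second hetero atom such as morpholin-4-yl, would give a step beyond the scatter. Going by these compounds, it is also open whether pyrrolidin-1-yl behaves the same way on the ethyl ester side chain of compound 2, which would show whether the two positions act independently in this assay.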